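Aziridinylquinone series: carbamate chain swapped for 1-methoxypropyl

The compounds below may be only part of what the source reports. "The series", "measured", "known", "first", "only" and "open" are said of these compounds alone.

Compound 1 `CC1=C(N2CC2)C(=O)C(CC(C)OC(N)=O)=C(N2CC2)C1=O` is the reference point of this set. In a functional assay on L1210 cells (Mus musculus), with a stated time of 12 days (on this read-out lower numbers stand for lower potency and higher numbers for higher potency (the scale is a negative logarithm)), compound 1 gives 5.79, the highest of the three numbers shown. Compound 3 `CC1=C(N2CC2)C(=O)C(C(C)COC(N)=O)=C(N2CC2)C1=O` gives 5.71, and the step of a number 0.08 log units lower from compound 1 to compound 3 (within the scatter) shows that moving the same seven-atom substituent pattern around changes little. Compound 2 `COCCC1=C(N2CC2)C(=O)C(CCOC)=C(N2CC2)C1=O` gives 5.31, which stands beyond the scatter below compound 1.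

Compound 4 `CCC(OC)C1=C(N2CC2)C(=O)C(C)=C(N2CC2)C1=O` is not yet measured. The change from compound 1 is a group of 5 heavy atoms (4 carbon, 1 oxygen; no ring) in place of a group of 7 heavy atoms (4 carbon, 1 nitrogen, 2 oxygen; no ring), on a double-bonded ring carbon. Among the measured compounds shown here, no measured step matches this change: the step from compound 1 to compound 3 keeps the group of 7 heavy atoms intact and is within the scatter, so it says nothing about its removal. For the measured compounds named here, compound 2, the only member without such a group, sits lower than compound 1, and that is the only pointer toward the direction in this assay. A downward step is therefore expected for compound 4, though uncertain. Compound 4 is estimated at 5.45, within 5.05 to 5.85, an expected step of a number 0.34 log units lower from compound 1 to compound 4 (beyond the scatter).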

Compound 4, logarithm of the reciprocal of the active concentration, log(1/C): 5.33
The estimate for compound 4 lay 0.12 log units above the measured number; measured number inside the range.
By their numbers in this assay, from the lowest: compounds 2 and 4 (each within the scatter of the next); then compounds 3 and 1 (each within the scatter of the next).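

Exchanging the group of 7 heavy atoms for 1-methoxypropyl on this double-bonded ring carbon gives a loss beyond the scatter in this assay, from either starting chain (a number 0.46 log units lower from compound 1 to compound 4 (beyond the scatter)) and (a number 0.38 log units lower from compound 3 to compound 4 (beyond the scatter)). The earlier step between the two chains of 7 heavy atoms stayed within the scatter (a number 0.08 log units lower from compound 1 to compound 3 (within the scatter)), so this position does respond in this read-out, though only modestly, when the group itself is replaced. The exchange also takes the count from 1 hydrogen-bond donor to 0 and from 2 hydrogen-bond acceptors to 1, but no measurement on hand explains the loss.

Which part of the exchange carries the loss remains open, as chain length and the donor change together in these pairs. A 1-hydroxypropyl group or a longer chain ending in an amine at this carbon would help separate them.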